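The source may report more compounds than this note shows. Statements on the series, on what has been measured and on what is new or still open speak of the compounds shown alone.

Within the data shown here, in a functional assay on the whole organism with Mus musculus as the target, with a stated time of 0.5 h (a lower number here means that less compound is needed, a higher number that more compound is needed for the effect), compound 1 `CCC1(c2ccccc2)OC(=O)N(C)C1=O` gives 45 mg/kg while compound 2 `CCC1(c2ccccc2)OC(=O)NC1=O` gives 39 mg/kg as its number, so compound 1 cannot be told apart from its only measured neighbour. The change to compound 3 `CC[C@@]1(c2ccccc2)OC(=O)N(C)C1=O` is this: the two compounds have the same atoms and bonds; at least one stereo element is drawn with a configuration in one of them and without one in the other: 1 of 1 stereo elements differ; a stereocentre at a saturated ring carbon is drawn without a configuration in compound 1 and S in compound 3 and so a stereocentre at a saturated ring carbon is drawn without a configuration in compound 1 and S in compound 3. Among the measured compounds shown here, the one measured step, a 1.2-fold lower number from compound 1 to compound 2 (0.06 log units; within the scatter) with hydrogen in place of methyl on an amide-type nitrogen in a ring, leaves this stereocentre untouched. No direction can be drawn from it, and no step beyond the scatter is expected in this assay on this evidence. The expected step is a 1.1-fold lower number from compound 1 to compound 3 (0.03 log units; within the scatter) in this estimate. Compound 3 is estimated at 42 mg/kg with 20 mg/kg to 90 mg/kg as the expected range.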

Compound 3, dose for half-maximal effect: 64 mg/kg
Compound 3: the middle estimate sits 1.5-fold (0.18 log units) below what was measured, and the stated range covers the measured number.
By their numbers in this assay, from the lowest: compounds 2, 1 and 3 (each within the scatter of the next).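

In this assay, specifying the stereocentre at the saturated ring carbon as S gives a 1.4-fold higher number from compound 1 to compound 3 (0.15 log units; within the scatter). Among these compounds, this is the first reading at this stereocentre, and on this step compound 3 cannot be told apart from compound 1. The comparison has one limit: the fact that one of compounds 1 and 3 is drawn with a defined configuration and the other without, at the place where they differ.

As far as these compounds go, the result of the opposite configuration remains open, so it cannot be said whether configuration at this stereocentre matters in this assay. Also open, from the compounds shown here alone, is what a longer chain or an amine at this stereocentre would do.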